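Replacing the amide aryl group while the shared core stays fixed

A few compounds are considered here, and "the series" means these few. Any claim that something is new, unique, unknown or untested is made for them only; others in the source may bear on it.

Compound 1 `COC(=O)c1cccc(NC(=O)C2CCCN(C(=O)c3cc(C(F)(F)F)cc(C(F)(F)F)c3)C2)c1`: 0%
Compound 2 `O=C(Nc1cccc(Oc2ccccc2)c1)C1CCCN(C(=O)c2cc(C(F)(F)F)cc(C(F)(F)F)c2)C1`: 1%
Compound 3 `O=C(Nc1cccc(Oc2nccc(C(F)(F)F)c2Cl)c1)C1CCCN(C(=O)c2cc(C(F)(F)F)cc(C(F)(F)F)c2)C1`: 0%

Three compounds sharing one core have been run in an ADME assay on PC-3 cells (Homo sapiens) for cytotoxicity, read by WST assay, tested at 100 uM; a higher number here means more inhibition at the concentration tested (going by the name of the read-out), a lower number less inhibition. In this assay compound 1 gives 0%, and compound 3 gives the same reading, so the two show no change at the digits reported. Among the compounds with values here, the only other measured value, that of compound 2, differs from compound 1 by a number 1 percentage points higher from compound 1 to compound 2 (within the scatter), a step inside the scatter; the steps of no change at the digits printed from compound 1 to compound 3 (within the scatter) and a number 1 percentage points lower from compound 2 to compound 3 (within the scatter) are likewise inside it. All three values thus sit together at the low end of the read-out.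

Compound 4 `O=C(Nc1ccc(Cl)nc1)C1CCCN(C(=O)c2cc(C(F)(F)F)cc(C(F)(F)F)c2)C1` has not yet been measured. Its difference from compound 1 is 6-chloropyridin-3-yl in place of 3-(methoxycarbonyl)phenyl on an amide-type nitrogen. Within the data shown here, none of the measured steps touches this position: each of them exchanges a substituent on the aromatic carbon of the anilide ring and leaves the ring itself on the amide nitrogen, whereas in compound 4 the whole aryl group is exchanged. Among the measured compounds shown here, those steps, all within the scatter, are the only guide available.

Compound 4 is therefore expected to show a number 1 percentage points higher from compound 1 to compound 4 (within the scatter), with no step beyond the scatter. The estimate for compound 4 in this assay is 1%, in a range from -6% to 12%.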

Compound 4, a percentage reported as inhibition, at one concentration (the size of the read-out at that concentration, not a potency): 25%
Compound 4: the middle estimate sits 24 percentage points below what was measured; the measured number lies above the stated range.
By their numbers in this assay, from the lowest: compounds 1, 3 and 2 (each within the scatter of the next); then compound 4.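

In this assay, within the data shown here, exchanging the whole aryl group on the amide-type nitrogen gives a number 25 percentage points higher from compound 1 to compound 4 (beyond the scatter), and this is the only step in the set that lies beyond the scatter. The substituent exchange on the aromatic carbon, seen in a number 1 percentage points higher from compound 1 to compound 2 (within the scatter), had left the reading within the scatter, so the earlier compounds gave no sign that the series could move in this read-out; the aryl group itself is now shown to be a place where a change in structure can register, with 6-chloropyridin-3-yl standing in for 3-(methoxycarbonyl)phenyl. No measurement at hand bears on why the reading rose.

The change replaces the carbon-only ring with a ring holding a hetero atom, brings in chlorine and removes the methoxycarbonyl group all at once, so the compounds shown do not tell which of these parts accounts for the step. A plain pyridin-3-yl without the chlorine, or a 4-chlorophenyl on the same amide-type nitrogen, would pull these apart, and an amine in place of the chlorine would test whether the chlorine itself matters.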